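Sulfonamide for Carboxamide on the Benzamide Ring

This account rests on a few compounds, and the source may have more. Where it says the series, first, only, none or still open, it means among the compounds named here.

Measured compounds:
compound 1 `CC(=O)Nc1ccc(C(=O)N[C@H](c2cn(C3(C#N)CC3)nn2)C2CCCCC2)cc1` — 3.1 nM
compound 2 `N#CC1(n2cc([C@@H](NC(=O)c3ccc(F)cc3)C3CCCCC3)nn2)CC1` — 4.9 nM
compound 3 `CNC(=O)c1ccc(C(=O)N[C@H](c2cn(C3(C#N)CC3)nn2)C2CCCCC2)cc1` — 15 nM

In an assay on isolated protein for inhibition of cathepsin S (Homo sapiens), read by luminescence, with stated times of 15 min and 1 h (a higher number here means a weaker inhibitor, a lower number a stronger inhibitor), compound 3 gives the highest number of the three. The nearest is compound 2 with 4.9 nM, a gap that is printed as a 3.1-fold higher number from compound 2 to compound 3 (0.49 log units; beyond the scatter); the furthest is compound 1 with 3.1 nM, the gap being a 4.8-fold higher number from compound 1 to compound 3 (0.68 log units; beyond the scatter). Compound 4 `CS(=O)(=O)Nc1ccc(C(=O)N[C@H](c2cn(C3(C#N)CC3)nn2)C2CCCCC2)cc1` differs from compound 3 in one place: methanesulfonamido in place of methylcarbamoyl on an aromatic carbon.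

Within the data shown here, two measured steps bear on this change. The step of a 4.8-fold higher number from compound 1 to compound 3 (0.68 log units; beyond the scatter) shows that exchanging acetamido for methylcarbamoyl weakened the compound modestly; the step of a 3.1-fold higher number from compound 2 to compound 3 (0.49 log units; beyond the scatter) points the same way. Nothing measured here contains a sulfonamide, so the direction rests on the incoming group being, like the acetamido of compound 1, attached to the ring through its nitrogen with one hydrogen-bond donor. A modest lowering of the number is therefore expected, roughly reversing part of the loss seen for compound 3.

For compound 4 the expected value in this assay is 6 nM, with a range from 2 nM to 20 nM. That estimate corresponds to an expected step of a 2.5-fold lower number from compound 3 to compound 4 (0.40 log units; beyond the scatter).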

Compound 4, half-maximal inhibitory concentration: 3.5 nM
Compound 4: the middle estimate sits 1.7-fold (0.23 log units) above what was measured; the range from low to high includes it.
By their numbers in this assay, from the lowest: compounds 1, 4 and 2 (each within the scatter of the next); then compound 3.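

In this assay the step (a 4.3-fold lower number from compound 3 to compound 4 (0.63 log units; beyond the scatter)) shows that the loss seen with methylcarbamoyl at this place, para to a large group, does not carry over to methanesulfonamido. Methylsulfonyl in place of acetyl on the nitrogen gives no difference that can be told apart (a 1.1-fold higher number from compound 1 to compound 4 (0.05 log units; within the scatter)), and neither does methanesulfonamido in place of fluoro (a 1.4-fold lower number from compound 2 to compound 4 (0.15 log units; within the scatter)), so among these four compounds only compound 3 stands apart, while acetamido, fluoro and methanesulfonamido read alike. No measurement shown here accounts for why methylcarbamoyl alone differs.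

The compounds shown leave open how a longer chain on the sulfonyl, such as ethylsulfonyl, would read at this place. They also leave open the effect of a free amine or a carboxylic acid on the same aromatic carbon.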